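Swapping an alkyl for a phenyl on the ester side chain

This account rests on a few compounds, and the source may have more. Where it says the series, first, only, none or still open, it means among the compounds named here.

Compound 1, `CC(C)=CC[C@@H](OC(=O)c1ccoc1)C1=CC(=O)c2c(O)ccc(O)c2C1=O`, in a functional assay on HeLa cells (Homo sapiens) for cytotoxicity, read by MTT assay (a lower number here means a stronger inhibitor, a higher number a weaker inhibitor), gives only a limit, > 100000 nM.
Compound 2, `CCC(C)(O)CC(=O)O[C@H](CC=C(C)C)C1=CC(=O)c2c(O)ccc(O)c2C1=O`, gives 25200 nM.
Compound 3, `CC[C@@](C)(O)CC(=O)O[C@H](CC=C(C)C)C1=CC(=O)c2c(O)ccc(O)c2C1=O`, gives 17900 nM.

Compound 3 has the lowest of the two numbers shown, though its gap to compound 2 is within the scatter, so the two cannot be ordered: a 1.4-fold lower number from compound 2 to compound 3 (0.15 log units; within the scatter). The piece follows the step to compound 4, `CC(C)=CC[C@@H](OC(=O)CC(C)(O)c1ccccc1)C1=CC(=O)c2c(O)ccc(O)c2C1=O`, where (1-hydroxy-1-phenylethyl in place of 1-hydroxy-1-methylpropyl on a saturated chain carbon bound to a carbonyl carbon). Going by the values given here, no measured step touches this part of the molecule. The two steps that do give numbers, an at least 3.9-fold lower number from compound 1 to compound 2 (0.59 log units; beyond the scatter) and an at least 5.5-fold lower number from compound 1 to compound 3 (0.74 log units; beyond the scatter), replace the group on the carbonyl carbon itself and rest on a limit, (the limit of > 100000 nM in this assay, at which 1 of the 3 values shown sits), so they say nothing about the change at hand. The third step is a difference only in drawn configuration, (the fact that one of compounds 2 and 3 is drawn with a defined configuration and the other without, at the place where they differ). Compound 4 is therefore expected to sit close to compound 3, with no step beyond the scatter in this assay in either direction: a 1.1-fold lower number from compound 3 to compound 4 (0.05 log units; within the scatter). The estimate for compound 4 is 16000 nM, between 5000 nM and 50000 nM.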

Compound 4, half-maximal inhibitory concentration: 85700 nM
The estimate for compound 4 lay 5.4-fold (0.73 log units) below the measured number; the measured number lies above the stated range.
By their numbers in this assay, from the lowest: compounds 3 and 2 (each within the scatter of the next); then compound 4. At a limit, above all of these: compound 1.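

In this assay, going by these compounds alone, this is the first measured change on a saturated chain carbon bound to a carbonyl carbon, and 1-hydroxy-1-phenylethyl in place of 1-hydroxy-1-methylpropyl gives a modest step to a weaker inhibitor (a 4.8-fold higher number from compound 3 to compound 4 (0.68 log units; beyond the scatter)). The same direction holds when phenyl replaces ethyl with no configuration drawn at that carbon in either compound (a 3.4-fold higher number from compound 2 to compound 4 (0.53 log units; beyond the scatter)), so the rise does not depend on the configuration drawn in compound 3. Compound 1 gives only a limit: the limit of > 100000 nM in this assay, at which 1 of the 4 values shown sits. The remaining step rests on that limit and cannot be read (an at least 1.1-fold lower number from compound 1 to compound 4 (0.06 log units; that floor lies within the scatter)).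

The compounds shown leave open whether a smaller group such as cyclopropyl, or a pyridine ring, would behave like the phenyl or like the ethyl. They also leave open whether a single drawn configuration at that carbon would change the number for compound 4.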